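Removing the Chloro Substituent Beside the Trifluoromethyl Group

The compounds below may be only part of what the source reports. "The series", "measured", "known", "first", "only" and "open" are said of these compounds alone.

Of the compounds shown here, two sharing one core have been measured in a functional assay on SN12C cells (Homo sapiens) for inhibition, read by sulforhodamine B assay, with a stated time of 48 h; on this read-out lower numbers stand for stronger inhibition of growth and higher numbers for weaker inhibition of growth. Compound 1 `O=C(Nc1cccc(-n2cc(-c3ccncc3)c(-c3ccc(Cl)c(O)c3)n2)c1)Nc1ccc(Cl)c(Cl)c1` gives 1310 nM in this assay. Compound 2 `COc1cc(-c2nn(-c3cccc(NC(=O)c4ccc(Cl)c(C(F)(F)F)c4)c3)cc2-c2ccncc2)ccc1Cl` gives 11200 nM in this assay, which is the higher of the two numbers, and its gap to compound 1 lies beyond the scatter of repeated measurements.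

Compound 3 `COc1cc(-c2nn(-c3cccc(NC(=O)c4cccc(C(F)(F)F)c4)c3)cc2-c2ccncc2)ccc1Cl` has not been measured. It differs from compound 2 in one place: hydrogen in place of chloro on an aromatic carbon. Cut one bond further out, the change reads 4-chloro-3-(trifluoromethyl)phenyl to 3-(trifluoromethyl)phenyl. Going by the values given here, no measured pair shows this kind of change, so the two values above offer no guide to its size. A small step is expected, if any, from compound 2 to compound 3 in this assay, of about a 1.4-fold higher number from compound 2 to compound 3 (0.15 log units; within the scatter) toward a slightly higher number. Compound 3 is accordingly estimated at 16000 nM in this assay, within a range of 5000 nM to 50000 nM.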

Compound 3, concentration for 50% growth inhibition: 3310 nM
Beside the measured number, compound 3's estimate is 4.8-fold (0.68 log units) above it; measured number below the stated range.
By their numbers in this assay, from the lowest: compound 1; then compound 3; then compound 2.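

In this assay the chloro group is shown to matter at this position, ortho to a trifluoromethyl group: replacing it with hydrogen gives a 3.4-fold lower number from compound 2 to compound 3 (0.53 log units; beyond the scatter), a step beyond the scatter. In this one pair, therefore, the 3-(trifluoromethyl)phenyl compound inhibits growth more strongly than its 4-chloro-3-(trifluoromethyl)phenyl partner, so the chloro group does not add to inhibition here. Compounds 1 and 2 differ in more than one place and could not isolate this effect, and no measurement offered here explains it.

On these data alone, it remains open whether a fluoro, a methyl group or a nitrile at this position would behave like hydrogen or like chloro. Also open, as far as these compounds go, is whether the same change would have a similar effect on the urea of compound 1, or with an amine on the ring in place of the trifluoromethyl group.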